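A pyridyl group in place of a pyrazolyl

The source may report more compounds than this note shows. Statements on the series, on what has been measured and on what is new or still open speak of the compounds shown alone.

Going by the values given here, compound 2 `C[C@H](NC(=O)c1cc(C(F)(F)F)nn1C)c1nc(-c2cnn(C)c2)no1` stands as the weaker of the two compounds measured so far in an assay on T-REx-293 cells for inhibition of potassium channel subfamily T member 1 (Homo sapiens), read by patch clamp (on this read-out lower numbers stand for stronger inhibition and higher numbers for weaker inhibition), where compound 2 gives 2640 nM. Its only companion, compound 1 `C[C@H](NC(=O)c1cc(C(F)(F)F)nn1C)c1nc(-c2cccc(F)c2)no1`, gives 136 nM in this assay. Among the compounds with values here, the one step between them is a 19-fold higher number from compound 1 to compound 2 (1.29 log units; beyond the scatter), a large loss that came with the exchange of the 3-fluorophenyl for the 1-methyl-1H-pyrazol-4-yl.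

Compound 3 `COCc1cc(-c2noc([C@H](C)NC(=O)c3cc(C(F)(F)F)nn3C)n2)ccn1` has not yet been measured. It differs from compound 2 in that (2-(methoxymethyl)pyridin-4-yl in place of 1-methyl-1H-pyrazol-4-yl on an aromatic carbon). Within the data shown here, the single measured step that bears on this change is the one from compound 1 to compound 2, since it concerns the same position and the same departing group, the 1-methyl-1H-pyrazol-4-yl. Because a 19-fold higher number from compound 1 to compound 2 (1.29 log units; beyond the scatter) was large, the departure of that group is expected to recover a good part, though not all, of what compound 2 had given up. The expected step is a 6.6-fold lower number from compound 2 to compound 3 (0.82 log units; beyond the scatter). In this assay compound 3 is therefore estimated at 400 nM, with a range from 120 nM to 1500 nM.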

Compound 3, half-maximal inhibitory concentration: 322 nM
Beside the measured number, compound 3's estimate is 1.2-fold (0.09 log units) above it; the range from low to high includes it.
By their numbers in this assay, from the lowest: compound 1; then compound 3; then compound 2.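

In this assay, the step from the 1-methyl-1H-pyrazol-4-yl to the 2-(methoxymethyl)pyridin-4-yl is an 8.2-fold lower number from compound 2 to compound 3 (0.91 log units; beyond the scatter), which shows that this place on the shared core does not lose most of its inhibition with every nitrogen-bearing aromatic ring. The six-membered ring with its methoxymethyl chain recovers much of the ground lost with the pyrazolyl, yet the step in the other direction, a 2.4-fold higher number from compound 1 to compound 3 (0.37 log units; beyond the scatter), is still beyond the scatter, so the 3-fluorophenyl of compound 1 keeps the lowest number of the three. No measurement is at hand that would explain either step.

The compounds shown leave open how much of the gain belongs to the pyridine ring and how much to the methoxymethyl chain, as the two enter together in compound 3. A plain pyridin-4-yl, or the same ring bearing an amine or a longer ether chain in place of the methoxymethyl, would separate the two parts and show whether the gap to compound 1 can be closed with a ring of this kind.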